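From ethoxy to 4-methoxybutoxy in compound 2

The compounds below may be only part of what the source reports. "The series", "measured", "known", "first", "only" and "open" are said of these compounds alone.

Compound 1 (`Cc1noc(CC2OC(=O)c3ccccc32)n1`) gives > 10000 nM in a functional assay on RAW264.7 cells (Mus musculus) for inhibition, read by Griess assay, with stated times of 1 h and 24 h (a higher number here means a weaker inhibitor, a lower number a stronger inhibitor), as a limit and not a number. Compound 2 (`CCOc1ccc(C(O)C2OC(=O)c3c(OC)cc(OC)cc32)cc1`) stands at > 10000 nM in this assay and so is also known only as a limit. Compound 3 (`CCCCCCOc1ccc(C(O)C2OC(=O)c3c(OC)cc(OC)cc32)cc1`) gives 5360 nM as a measured number. Compound 4 (`COCCCCOc1ccc(C(O)C2OC(=O)c3c(OC)cc(OC)cc32)cc1`) differs from compound 2 by 2-methoxyethyl in place of hydrogen on a saturated chain carbon, two bonds along the chain from an oxygen on an aromatic ring and thus carries 4-methoxybutoxy in place of ethoxy. Butyl in place of hydrogen at that same place gave the only measured step bearing on this (an at least 1.8-fold lower number from compound 2 to compound 3 (0.27 log units; that floor lies within the scatter)), whose size remains open given the limit of > 10000 nM in this assay, at which 2 of the 3 values shown sit, as its starting point. A similar small move towards a lower number is therefore expected, and a second reading at the limit remains quite possible. The expected step is an at least 1.2-fold lower number from compound 2 to compound 4 (0.09 log units; that floor lies within the scatter) and lies on that same small scale. For compound 4 the estimated value is 8000 nM with an expected range from 3500 nM to 16000 nM in this assay overall.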

Compound 4, half-maximal inhibitory concentration: 8210 nM
The estimate for compound 4 lay 1.0-fold (0.01 log units) below the measured number; low and high end bracket the measured number.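

With a second extended chain, compound 4 gives a measured number in this assay, and the step reads an at least 1.2-fold lower number from compound 2 to compound 4 (0.08 log units; that floor lies within the scatter). Its true size stays open, because compound 2 is known only as a limit: the limit of > 10000 nM in this assay, at which 2 of the 4 values shown sit.

The chain end is new information: methoxy in place of ethyl, four bonds along the chain from the oxygen on the aromatic ring, gives a 1.5-fold higher number from compound 3 to compound 4 (0.19 log units; within the scatter), so compound 3 and compound 4 cannot be told apart here.

On these data alone, whether a longer chain or an amine at the chain end would move the number beyond the scatter remains open.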